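The source may report more compounds than this note shows. Statements on the series, on what has been measured and on what is new or still open speak of the compounds shown alone.

Measured compounds in this series:

compound 1, `O=c1[nH]nc2n(c1=O)CCN2c1ccccc1`: 0%
compound 2, `N=c1c(=O)[nH]nc2n1CCN2c1ccc(Cl)cc1`: 16%
compound 3, `Cc1ccc(N2CCn3c2n[nH]c(=O)c3=O)cc1`: 14%

Of the compounds shown here, three share one core and have been tested in a functional assay on T47D cells (Homo sapiens) for cytotoxicity, with a stated time of 72 h, tested at 10 ug/mL; a higher number here means a stronger effect of the compound at the concentration tested, a lower number a weaker effect. Compound 1 gives 0% in this assay, compound 2 gives 16% and compound 3 gives 14%. Compound 2 carries the highest of the three numbers, but compound 3 sits within the scatter of it; only compound 1 lies beyond the scatter below compound 2.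

The next compound is compound 4, `Cc1ccc(N2CCn3c2n[nH]c(=O)c3=N)cc1`, which differs from compound 2 by methyl in place of chloro on an aromatic carbon.

Among the measured compounds shown here, the one measured step that touches the same position is a number 14 percentage points higher from compound 1 to compound 3 (beyond the scatter), which concerns methyl in place of hydrogen, not methyl in place of chloro. For the measured compounds named here, no measured pair shows chloro exchanged for methyl directly, so the size of the change from compound 2 to compound 4 is not fixed by the data. Compound 3, which also carries methyl on that ring, gives 14%, close to compound 2. The step expected in this assay is therefore a number 1 percentage points lower from compound 2 to compound 4 (within the scatter), within the scatter. Compound 4 is estimated to give 15% in this assay, with a range from 4% to 27%.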

Compound 4, a percentage reported as inhibition, at one concentration (the size of the read-out at that concentration, not a potency): 0%
For compound 4 the middle estimate is 15 percentage points above the measured one, and the stated range ends above it.
By their numbers in this assay, from the lowest: compounds 1 and 4 (each within the scatter of the next); then compounds 3 and 2 (each within the scatter of the next).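

In this assay, among the compounds shown here, methyl in place of chloro on an aromatic carbon para to a large group gives a number 16 percentage points lower from compound 2 to compound 4 (beyond the scatter), the first measured exchange of one substituent for another at this place, and it shows that the choice between these two groups can move the read-out beyond the scatter. The same methyl also does not give one fixed value across the series: where compound 4 has an imine, compound 3 has a carbonyl, and compound 3 gives 14% in this comparison, whereas compound 4 gives 0% here, so a group at this place cannot be judged apart from the rest of the compound. No measurement at hand explains the step.

The compounds shown leave open how the imine compounds behave with hydrogen at this place, and whether chloro on the carbonyl compounds would match the value of compound 2. For the compounds shown here, they also leave open what a methoxy group, an amine or a carboxylic acid would give at this place, and with only two substituent exchanges read here, no trend across groups can yet be stated.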